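Piperidin-1-yl in place of pyrrolidin-1-yl on compound 3

The source may hold more compounds than are shown below. What is called first, only, known or untested is meant among the compounds shown, and "the series" means these compounds.

Three compounds in this series have measurements so far, all in a functional assay on MES-SA cells (Homo sapiens) for inhibition, with a stated time of 72 h (a higher number here means a weaker inhibitor, a lower number a stronger inhibitor), under the same conditions. Compound 1 (`Oc1c(CN2CCCC2)ccc2cccnc12`) gives 4640 nM; 4570 nM (2 entries) in its repeat entries. Compound 2 (`CC(C)OCc1cc(CN2CCCCC2)c(O)c2ncccc12`) gives 6030 nM in the same read-out. Compound 3 (`Oc1c(C(c2ccncc2)N2CCCC2)ccc2cccnc12`) gives 5890 nM and so stands level with compound 2 within the scatter, and compound 1 also lies within the scatter of both.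

Compound 4 (`Oc1c(C(c2ccncc2)N2CCCCC2)ccc2cccnc12`) is the next to be read. It carries piperidin-1-yl in place of the pyrrolidin-1-yl of compound 3, on a saturated chain carbon bound to two aromatic carbons (piperidin-1-yl in place of pyrrolidin-1-yl on a saturated chain carbon bound to two aromatic carbons).

Within the data shown here, no measured pair isolates this change, so any expectation rests on the close grouping of the three values. Compound 2, which also bears a piperidin-1-yl group, reads 6030 nM in that same group. The expected step of a 1.2-fold lower number from compound 3 to compound 4 (0.07 log units; within the scatter) is small, with no movement beyond the scatter in either direction in this assay at this stage. The estimated value for compound 4 is 5000 nM with an expected range of 2500 nM to 10000 nM around it.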

Compound 4, half-maximal inhibitory concentration: 15500 nM
Compound 4: middle estimate off by 3.1-fold (0.49 log units), on the low side; the whole stated range lies below it.
By their numbers in this assay, from the lowest: compounds 3 and 2 (each within the scatter of the next); then compound 4.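

In this assay, among these compounds, the exchange of pyrrolidin-1-yl for piperidin-1-yl on a saturated chain carbon bound to two aromatic carbons gives a 2.6-fold higher number from compound 3 to compound 4 (0.42 log units; beyond the scatter), the first measured step between compounds that differ in one place. This position therefore responds to the ring size of the amine, with the six-membered ring on the side of the higher number, although the step is only modest and the pair gives no reason for it. Compound 3 and compound 4 each rest on a single entry, while the one compound with repeat entries shows close agreement between them: the several entries of compound 1 in this assay, 4640 nM; 4570 nM (2 entries)

The compounds shown leave open whether the response follows ring size as such or depends on the ring's make-up, which morpholin-4-yl, azepan-1-yl or an open-chain dimethylamino group at the same carbon would help to separate. They also leave open whether piperidin-1-yl in place of pyrrolidin-1-yl on compound 1 would give a step of like direction and size, so the effect cannot yet be extended beyond this one pair.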